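This account rests on a few compounds, and the source may have more. Where it says the series, first, only, none or still open, it means among the compounds named here.

Measured so far:
Compound 1, `COc1ccc(-c2nnc(NC(=O)/C=C/c3ccccc3)s2)cc1`: 0.68 ug/mL
Compound 2, `O=C(/C=C/c1ccccc1)Nc1nnc(-c2ccccc2)s1`: 1.75 ug/mL
Compound 3, `Cc1ccc(-c2nnc(NC(=O)/C=C/c3ccccc3)s2)cc1`: 1.38 ug/mL

These three share one core and were tested in a functional assay on A549 cells (Homo sapiens) for antiproliferative activity, read by MTT assay, with a stated time of 48 h; a lower number here means a stronger inhibitor, a higher number a weaker inhibitor. Compound 1 gives the lowest number of the three: a 2.6-fold higher number from compound 1 to compound 2 (0.41 log units; beyond the scatter) and a 2.0-fold higher number from compound 1 to compound 3 (0.31 log units; beyond the scatter), both beyond the scatter. Compound 4, `COc1ccc(-c2nnc(NC(=O)/C=C/c3ccc(C)cc3)s2)cc1`, has not yet been measured; it differs from compound 1 by methyl in place of hydrogen on an aromatic carbon. Among the compounds with values here, the one measured step of the same kind, methyl in place of hydrogen on an aromatic carbon, is a 1.3-fold lower number from compound 2 to compound 3 (0.10 log units; within the scatter), which lies within the scatter. No step beyond the scatter is therefore expected in this assay for compound 4. The expected step is a 1.1-fold higher number from compound 1 to compound 4 (0.04 log units; within the scatter). Compound 4 is estimated at 0.75 ug/mL, with a range from 0.35 ug/mL to 1.6 ug/mL.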

Compound 4, half-maximal inhibitory concentration: 0.58 ug/mL
Beside the measured number, compound 4's estimate is 1.3-fold (0.11 log units) above it; measured number inside the range.
By their numbers in this assay, from the lowest: compounds 4 and 1 (each within the scatter of the next); then compounds 3 and 2 (each within the scatter of the next).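

In this assay, changing phenyl to 4-methylphenyl gives a 1.2-fold lower number from compound 1 to compound 4 (0.07 log units; within the scatter), so this position accepts a methyl without a step beyond the scatter, even with the methoxy group of compound 1 kept in place. Until now, this change had been seen on only one core, and it now stays small on a second: the same change on two cores in this assay, a 1.3-fold lower number (0.10 log units; within the scatter) from compound 2 to compound 3 and a 1.2-fold lower number (0.07 log units; within the scatter) from compound 1 to compound 4, 1.1-fold (0.03 log units) apart, within the scatter of two such steps

Still open, on these data alone, is whether a larger or differently built group at this position, such as an amine, a carboxylic acid or a longer chain, would shift the number beyond the scatter.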